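A few compounds are considered here, and "the series" means these few. Any claim that something is new, unique, unknown or untested is made for them only; others in the source may bear on it.

Compound 3 `Cc1cccc(Cn2c(CN3CCN(C(=O)c4cccnc4)CC3)nc3ccccc32)c1` gives 24.5% in an assay on isolated protein for inhibition of aldehyde dehydrogenase 1A1 (Homo sapiens), read by spectrophotometry, tested at 10 uM (on this read-out lower numbers stand for less inhibition and higher numbers for more inhibition at the one concentration tested (going by the name of the read-out)), the lowest of the three numbers recorded; its nearest neighbour is compound 2 `Cc1cccc(Cn2c(CN3CCN(C(=O)C4CCCCC4)CC3)nc3ccccc32)c1` with 31.9%, a gap of a number 7.4 percentage points lower from compound 2 to compound 3 (within the scatter), while compound 1 `CCC(=O)N1CCN(Cc2nc3ccccc3n2Cc2cccc(C)c2)CC1` with 85.1% lies furthest away, by a number 60.6 percentage points lower from compound 1 to compound 3 (beyond the scatter). Compound 4 `Cc1cccc(Cn2c(CN3CCN(C(=O)C4CCC4)CC3)nc3ccccc32)c1` differs from compound 3 in one place: cyclobutyl in place of pyridin-3-yl on a carbonyl carbon. Among the compounds with values here, the steps that bear on this are the drop of a number 53.2 percentage points lower from compound 1 to compound 2 (beyond the scatter) when a cyclohexyl ring replaces ethyl, and the flat move of a number 7.4 percentage points lower from compound 2 to compound 3 (within the scatter) between the two rings. A cyclobutyl ring is expected to sit between these cases, so a rise of a number 25.5 percentage points higher from compound 3 to compound 4 (beyond the scatter) is estimated for compound 4. Compound 4 is therefore expected to give about 50%, between 25% and 80%.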

Compound 4, a percentage reported as inhibition, at one concentration (the size of the read-out at that concentration, not a potency): 69.1%
The estimate for compound 4 lay 19.1 percentage points below the measured number; low and high end bracket the measured number.
By their numbers in this assay, from the lowest: compounds 3 and 2 (each within the scatter of the next); then compound 4; then compound 1.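

In this assay, a ring on the carbonyl carbon does not by itself bring the number down: cyclobutyl gives a number 44.6 percentage points higher from compound 3 to compound 4 (beyond the scatter) and a number 37.2 percentage points higher from compound 2 to compound 4 (beyond the scatter). Ethyl still stays ahead of cyclobutyl, with a number 16 percentage points lower from compound 1 to compound 4 (beyond the scatter), so the smaller ring recovers much of the loss but not all of it. No evidence at hand accounts for these differences. On these data alone, it remains open whether the number follows ring size steadily, and where a cyclopropyl ring, a cyclopentyl ring or a longer chain such as butyl on the same carbonyl carbon would fall.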